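A Nitro Group in Place of Methoxy

The source may report more compounds than this note shows. Statements on the series, on what has been measured and on what is new or still open speak of the compounds shown alone.

Compound 1, `COc1cc(C2=CC(c3cc(OC)c(OC)c(OC)c3)NC(=S)N2)cc(OC)c1OC`: in a functional assay on L1210 cells (Mus musculus) for cytotoxicity, read by MTT assay, with a stated time of 72 h (a higher number here means a weaker inhibitor, a lower number a stronger inhibitor), compound 1 gives > 100000 nM, a limit of the assay and not a number.
Compound 2, `COc1ccc(C2C=C(c3cc(OC)c(OC)c(OC)c3)NC(=S)N2)cc1OC`: in this assay compound 2 gives 56300 nM.
Compound 3, `COc1cccc(C2C=C(c3cc(OC)c(OC)c(OC)c3)NC(=S)N2)c1`: in this assay compound 3 gives > 100000 nM, again a limit and not a number.

Within the data shown here, compound 2 holds the only number in this assay; the other two values are limits. The two measured steps each remove a methoxy from an aromatic carbon: an at least 1.7-fold lower number from compound 1 to compound 2 (0.24 log units; that floor lies within the scatter) and an at least 1.7-fold higher number from compound 2 to compound 3 (0.24 log units; that floor lies within the scatter). Each is only a floor within the scatter because both steps reach (the limit of > 100000 nM in this assay, at which 2 of the 3 values shown sit).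

Compound 4, `COc1ccc(C2C=C(c3cc(OC)c(OC)c(OC)c3)NC(=S)N2)cc1[N+](=O)[O-]`, is not yet measured. It differs from compound 2 in one place: nitro in place of methoxy on an aromatic carbon. Neither measured step exchanges one group for another; both merely remove methoxy, so they speak to this change only indirectly, and no measured value here separates a nitro from a methoxy. The expectation for compound 4 in this assay is therefore a step of a 1.2-fold higher number from compound 2 to compound 4 (0.09 log units; within the scatter), not clearly beyond the scatter, with a real chance that only a limit is returned. Compound 4 is estimated at 70000 nM, expected within 20000 nM to 200000 nM.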

Compound 4, half-maximal inhibitory concentration: > 100000 nM
Compound 4: no number, only a limit (the forecaster's own chance of this, stated with the estimate: 45%); at least 1.4-fold (0.15 log units) between middle value and limit.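

Unlike the earlier steps, which only remove a methoxy, this one exchanges the methoxy ortho to a methoxy group for nitro, and in this assay it comes to an at least 1.7-fold higher number from compound 2 to compound 4 (0.24 log units; that floor lies within the scatter), with the other methoxy of compound 2 left in place. Compound 4 gives > 100000 nM, a limit of the assay and not a number. Compound 3 keeps the methoxy at this place and loses the other one, so a change at either methoxy of compound 2 has now ended at a limit, and the step to compound 4 stays a floor within the scatter because that compound too reaches it: the limit of > 100000 nM in this assay, at which 3 of the 4 values shown sit.

As far as these compounds go, how far compound 4 really lies from compound 2 remains unknown, so the data cannot tell whether nitro differs from methoxy at this place by more than the scatter. Among these compounds, also open is whether an amine, a hydroxyl or a plain hydrogen at this same aromatic carbon would give a number in this assay at all, and how that number would compare with the one for compound 2.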